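Double-bond geometry in the acetoxymethyl enone series

A few compounds are considered here, and "the series" means these few. Any claim that something is new, unique, unknown or untested is made for them only; others in the source may bear on it.

The series shares one core, carrying an acetoxymethyl group and a benzoyl group on the double bond, with the aryl ring at the far end varied. Compound 1 `CC(=O)OC/C(=C\c1ccc(Cl)cc1)C(=O)c1ccccc1` gives 5300 nM in a functional assay on T47D cells (Homo sapiens) for inhibition, read by sulforhodamine B assay, with a stated time of 48 h; a higher number here means a weaker inhibitor of growth, a lower number a stronger inhibitor of growth. Compound 2 `CC(=O)OC/C(=C\c1ccc(F)cc1)C(=O)c1ccccc1` gives 14000 nM in this assay, and compound 3 `CC(=O)OC/C(=C\c1ccccc1Br)C(=O)c1ccccc1` gives 17000 nM. Compound 3 therefore carries the highest of the three numbers; against compound 2 it sits within the scatter, against compound 1 it lies beyond it, as the steps of a 2.6-fold higher number from compound 1 to compound 2 (0.42 log units; beyond the scatter), a 3.2-fold higher number from compound 1 to compound 3 (0.51 log units; beyond the scatter) and a 1.2-fold higher number from compound 2 to compound 3 (0.08 log units; within the scatter) show.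

Compound 4 `CC(=O)OC/C(=C/c1ccccc1Br)C(=O)c1ccccc1` is the next member. Relative to compound 3 the change is the two compounds have the same atoms and bonds and differ only in configuration as drawn: 1 of 1 stereo elements differ; a double bond is drawn E in compound 3 and Z in compound 4. For the measured compounds named here, none of the three measured steps concerns geometry: each swaps the aryl ring or its halogen while the double bond stays drawn E. No measured pair therefore bears on the step from compound 3 to compound 4, and there is no basis in these data for expecting a shift in either direction beyond the scatter in this assay.

Compound 4 is accordingly estimated at 17000 nM, with a range of 5000 nM to 55000 nM, meaning an expected step of no change at the digits printed from compound 3 to compound 4 (within the scatter) that is deliberately kept wide.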

Compound 4, concentration for 50% growth inhibition: 18000 nM
Compound 4: the middle estimate sits 1.1-fold (0.02 log units) below what was measured; the range from low to high includes it.
By their numbers in this assay, from the lowest: compound 1; then compounds 2, 3 and 4 (each within the scatter of the next).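

In this assay, for the compounds shown here, drawing the double bond Z rather than E gives a 1.1-fold higher number from compound 3 to compound 4 (0.02 log units; within the scatter), the first reading of geometry, and with the 2-bromophenyl group in place the two geometries cannot be told apart by their numbers. The reading isolates this one feature, with nothing else varied: the fact that compounds 3 and 4 differ only in the configuration as drawn. Among the steps read so far, those that exceed the scatter both start from compound 1, such as a 3.2-fold higher number from compound 1 to compound 3 (0.51 log units; beyond the scatter), and each of them swaps the aryl ring or its halogen, whereas the single geometry step stays within the scatter.

An E and Z pair is available only for the 2-bromophenyl member, and whether geometry is equally silent with the 4-chlorophenyl group of compound 1 remains an open question. Every compound shown also keeps the acetoxymethyl and benzoyl groups unchanged, leaving open how the number would respond to a hydroxymethyl or aminomethyl group in place of acetoxymethyl, or to a carboxylic acid on the benzoyl ring.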